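From pyridin-4-yl to naphthalen-1-yl on the piperazine nitrogen

A few compounds are considered here, and "the series" means these few. Any claim that something is new, unique, unknown or untested is made for them only; others in the source may bear on it.

Three compounds share one core and differ only in the group on an amine nitrogen in a ring. Compound 1 `Nc1scc(CN2CCN(c3cc(Cl)cc(Cl)c3)CC2)c1C(=O)c1ccc(Cl)cc1` carries 3,5-dichlorophenyl there and in a functional assay on CHO cells with adenosine receptor A1 (Homo sapiens) as the target, read by cAMP accumulation and immunoassay, with a stated time of 6 min, tested at 1 uM (on this read-out lower numbers stand for a stronger effect and higher numbers for a weaker effect at the one concentration tested), compound 1 gives -69%. Compound 2 `Nc1scc(CN2CCN(c3ccc([N+](=O)[O-])cc3)CC2)c1C(=O)c1ccc(Cl)cc1` carries 4-nitrophenyl and gives -8.3%. Compound 3 `Nc1scc(CN2CCN(c3ccncc3)CC2)c1C(=O)c1ccc(Cl)cc1` carries pyridin-4-yl and gives -8.3%. Compound 3 thus stands level with compound 2, the two together at the top of the three numbers, and far from compound 1: a number 60.7 percentage points higher from compound 1 to compound 3 (beyond the scatter), just as a number 60.7 percentage points higher from compound 1 to compound 2 (beyond the scatter), while no change at the digits printed from compound 2 to compound 3 (within the scatter).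

Compound 4 `Nc1scc(CN2CCN(c3cccc4ccccc34)CC2)c1C(=O)c1ccc(Cl)cc1` is not yet measured. Its change from compound 3 is naphthalen-1-yl in place of pyridin-4-yl on an amine nitrogen in a ring. For the measured compounds named here, no measured step brings naphthalen-1-yl in, so the two large steps away from compound 1 and the flat step between compounds 2 and 3 only show that this position can move the read-out widely. A step of a number 31.7 percentage points lower from compound 3 to compound 4 (beyond the scatter) is therefore expected, downward but uncertain. Compound 4 is estimated at -40%, within -80% to 0%.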

Compound 4, a percentage reported as activity, at one concentration (the size of the read-out at that concentration, not a potency): 2.9%
For compound 4 the middle estimate is 42.9 percentage points below the measured one, outside the stated range (above it).
By their numbers in this assay, from the lowest: compound 1; then compounds 2 and 3 (each within the scatter of the next); then compound 4.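

Placing naphthalen-1-yl on this amine nitrogen in a ring gives the highest number of the four in this assay (a number 11.2 percentage points higher from compound 3 to compound 4 (beyond the scatter); a number 11.2 percentage points higher from compound 2 to compound 4 (beyond the scatter)). Both of these steps are modest, whereas the step from the dichlorinated group is large (a number 71.9 percentage points higher from compound 1 to compound 4 (beyond the scatter)). A larger group with two six-membered aromatic rings of carbon only therefore does not reproduce the low number of compound 1, so neither size nor an all-carbon ring system alone tracks the read-out across these four compounds. Nothing measured here explains the shift. Still open, going by these compounds, is whether the two chlorines of 3,5-dichlorophenyl set compound 1 apart, and plain phenyl, 3-chlorophenyl or naphthalen-2-yl on the same nitrogen would test this.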